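This account rests on a few compounds, and the source may have more. Where it says the series, first, only, none or still open, it means among the compounds named here.

- Compound 1 `O=C(NCc1ccc(S(=O)(=O)c2ccccc2)cc1)c1nc2cnccc2[nH]1`: 73%
- Compound 2 `O=C(NCc1ccc(S(=O)(=O)c2ccccc2)cc1)c1cc2ccncc2s1`: 48%
- Compound 3 `O=C(NCc1ccc(S(=O)(=O)c2ccccc2)cc1)c1cc2ncccc2s1`: 81%

Compound 3 stands at the upper end of the numbers in an ADME assay on microsomes from liver (Homo sapiens) for metabolic stability, read by LC-MS, with a stated time of 30 min, tested at 1 uM (on this read-out higher numbers stand for a more stable compound and lower numbers for a less stable compound), level with compound 1 and clear of compound 2. The measured steps show a number 8 percentage points higher from compound 1 to compound 3 (within the scatter) and a number 33 percentage points higher from compound 2 to compound 3 (beyond the scatter).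

Compound 4 `O=C(NCc1ccc(S(=O)(=O)c2ccccc2)cc1)c1ccc2nccn2c1` differs from compound 3 at one place, on a carbonyl carbon: a group of 9 heavy atoms (7 carbon, 2 nitrogen; one five-membered aromatic ring with 2 hetero atoms, one six-membered aromatic ring with 1 hetero atom) in place of a group of 9 heavy atoms (7 carbon, 1 nitrogen, 1 sulfur; one five-membered aromatic ring with 1 hetero atom, one six-membered aromatic ring with 1 hetero atom), on a carbonyl carbon.

Exchanges at this same place bear on it. They also gave a number 25 percentage points lower from compound 1 to compound 2 (beyond the scatter), so such a swap can do little or a lot, in either direction. With two of the three numbers high and one clearly lower, a modest fall is expected. The estimated step is a number 15 percentage points lower from compound 3 to compound 4 (beyond the scatter). For compound 4 the expected value is 66%, with an estimated range of 42% to 85%.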

Compound 4, percent of the compound remaining: 77%
Estimate against measurement, compound 4: 11 percentage points below; measured number inside the range.
By their numbers in this assay, from the lowest: compound 2; then compounds 1, 4 and 3 (each within the scatter of the next).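

In this assay the group with 7 carbon and 2 nitrogen atoms gives a number 4 percentage points lower from compound 3 to compound 4 (within the scatter) and also a number 4 percentage points higher from compound 1 to compound 4 (within the scatter) so a third, differently built pair of fused rings on this carbonyl carbon holds up as well as the two best earlier ones. Compound 2 now stands alone, with a number 29 percentage points higher from compound 2 to compound 4 (beyond the scatter) as the clear gap in the set. High numbers here therefore do not depend on one particular ring pair.

From the compounds shown here alone, whether a ring pair carrying an amine or a carboxylic acid would keep this stability remains open. Nothing available explains why compound 2 stands apart.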